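Isobutylsulfanyl for isopropoxy: a small step expected

The compounds below may be only part of what the source reports. "The series", "measured", "known", "first", "only" and "open" are said of these compounds alone.

Of the compounds shown here, three sharing one core have been measured in a functional assay on aorta (VSMC cells, Rattus norvegicus); on this read-out lower numbers stand for an effect already at smaller amounts and higher numbers for an effect only at larger amounts of compound. There, compound 1 `O=S1(=O)N=C(SCc2ccccc2)Nc2ccc(Cl)cc21` gives 5400 nM, compound 2 `CC(C)SC1=NS(=O)(=O)c2cc(Cl)ccc2N1` gives 23000 nM, and compound 3 `CC(C)OC1=NS(=O)(=O)c2cc(Cl)ccc2N1` gives 22700 nM. Compound 3 thus stands level with compound 2, and both carry clearly higher numbers than compound 1.

The next compound, compound 4 `CC(C)CSC1=NS(=O)(=O)c2cc(Cl)ccc2N1`, has isobutylsulfanyl in place of isopropoxy on a carbon with a double bond to nitrogen.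

Going by the values given here, two measured steps bear on this change. Isopropoxy in place of isopropylsulfanyl gave a 1.0-fold lower number from compound 2 to compound 3 (0.01 log units; within the scatter), so the exchange of oxygen for sulfur alone is expected to count for little. Isopropyl in place of benzyl on a sulfur gave a 4.3-fold higher number from compound 1 to compound 2 (0.63 log units; beyond the scatter), a modest step and the only one here beyond the scatter. Among the compounds with values here, it shows that the group on the sulfur can shift the number, but no measured compound carries isobutyl, so the size of any such shift remains uncertain. Only a slight move towards a lower number is expected, with the expected step being a 1.5-fold lower number from compound 3 to compound 4 (0.18 log units; within the scatter). The estimate for compound 4 is 15000 nM, with an expected range from 6500 nM to 32000 nM.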

Compound 4, half-maximal effective concentration: 6200 nM
Beside the measured number, compound 4's estimate is 2.4-fold (0.38 log units) above it; measured number outside the range, below it.
By their numbers in this assay, from the lowest: compounds 1 and 4 (each within the scatter of the next); then compounds 3 and 2 (each within the scatter of the next).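

The group on the sulfur turns out to matter even when the change is small: isobutyl in place of isopropyl on a sulfur gave a 3.7-fold lower number from compound 2 to compound 4 (0.57 log units; beyond the scatter) in this assay, whereas before only the exchange of benzyl for isopropyl had moved the number beyond the scatter. The change from isopropoxy to isobutylsulfanyl on a carbon with a double bond to nitrogen gave a 3.7-fold lower number from compound 3 to compound 4 (0.56 log units; beyond the scatter), and since compound 2 and compound 3 stand within the scatter of each other, this step is best read as coming from the isobutyl group and not from the exchange of oxygen for sulfur. Isopropyl in place of phenyl on a saturated chain carbon bound to a sulfur gave a 1.1-fold higher number from compound 1 to compound 4 (0.06 log units; within the scatter), so in this assay a phenyl group on that chain is not required to reach the level of compound 1.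

The compounds shown leave open whether a longer chain or an amine at this position would go further, and whether isobutyl on an oxygen would match isobutyl on a sulfur. Nothing shown offers an explanation for these steps.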